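Swapping the Anilide Group on Compound 2

A few compounds are considered here, and "the series" means these few. Any claim that something is new, unique, unknown or untested is made for them only; others in the source may bear on it.

Compound 1 `O=C(CN1CCN(c2nnc(Cc3ccncc3)c3ccccc23)CC1)Nc1cccc(F)c1`: 4600 nM
Compound 2 `O=C(CN1CCN(c2nnc(Cc3ccccc3)c3ccccc23)CC1)Nc1ccc(Br)cc1`: 2000 nM

In a functional assay on A549 cells (Homo sapiens) for cytotoxicity, read by MTT assay, with a stated time of 72 h (a higher number here means a weaker inhibitor, a lower number a stronger inhibitor), compound 2 gives 2000 nM, the lower of the two numbers and therefore the stronger result. Compound 1 gives 4600 nM, and this gap lies beyond the usual scatter of repeated measurements.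

Compound 3 `O=C(CN1CCN(c2nnc(Cc3ccccc3)c3ccccc23)CC1)Nc1cccc(F)c1` has not yet been measured. Its structure departs from that of compound 2 in one place: 3-fluorophenyl in place of 4-bromophenyl on an amide-type nitrogen. In plain terms, it has 3-fluorophenyl in place of 4-bromophenyl on an amide-type nitrogen.

Among the compounds with values here, no measured pair isolates this change, so any forecast is uncertain. Compound 1 also carries 3-fluorophenyl and gives 4600 nM, so a modest rise in the number in this assay is expected, toward a weaker inhibitor. The estimated change is a 1.6-fold higher number from compound 2 to compound 3 (0.20 log units; within the scatter). Compound 3 is expected at 3200 nM, with an estimated range of 1300 nM to 7500 nM.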

Compound 3, half-maximal inhibitory concentration: 130000 nM
Compound 3: the middle estimate sits 41-fold (1.61 log units) below what was measured; the measured number lies above the stated range.
By their numbers in this assay, from the lowest: compound 2; then compound 1; then compound 3.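

In this assay the group on the amide-type nitrogen proves to matter a great deal: 3-fluorophenyl in place of 4-bromophenyl gives a 65-fold higher number from compound 2 to compound 3 (1.81 log units; beyond the scatter) even though both groups hold the same number of heavy atoms and a single carbon ring. The far end of the molecule matters just as clearly, as phenyl in place of pyridin-4-yl on the saturated chain carbon gives a 28-fold higher number from compound 1 to compound 3 (1.45 log units; beyond the scatter) when 3-fluorophenyl stays fixed on the amide. Nothing available here explains either step.

The first step changes both the halogen and its ring position, so the compounds shown cannot separate those two changes. A 4-fluorophenyl or 3-bromophenyl group on the amide nitrogen would separate them, and an unsubstituted phenyl there would show what either halogen contributes.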